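The compounds below may be only part of what the source reports. "The series", "measured", "known", "first", "only" and "open" are said of these compounds alone.

Measured compounds, with their readings:

Compound 1, `Cc1cc(Nc2cc(Cl)c(Cl)c(Cl)c2)nc(N)n1`: in an assay on cells for inhibition of S-adenosylmethionine decarboxylase proenzyme (Homo sapiens), read by mass spectrometry, at pH 7.2 (a higher number here means a weaker inhibitor, a lower number a stronger inhibitor), compound 1 gives > 63000 nM, which is a limit of the assay rather than a number.
Compound 2, `Cc1cc(Nc2cc(Cl)c(O)c(Cl)c2)nc(N)n1`: in this assay compound 2 gives > 180000 nM, again a limit.
Compound 3, `Cc1cc(Nc2cc(Cl)c(OC(F)F)c(Cl)c2)nc(N)n1`: in this assay compound 3 gives > 63000 nM, also a limit.

So compound 3 stands at a limit, and the two further values shown are limits too; none of the three compounds has a measurable number. The unmeasured compound 4, `Cc1cc(Nc2cc(Cl)c(N(C)C)c(Cl)c2)nc(N)n1`, differs from compound 3 by dimethylamino in place of difluoromethoxy on an aromatic carbon.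

For the measured compounds named here, three measured steps touch the same position of the shared core. The step that the two limits leave unreadable from compound 1 to compound 2, the step that the two limits leave unreadable from compound 1 to compound 3 and the step that the two limits leave unreadable from compound 2 to compound 3 are all unreadable because their endpoints sit at the limit of > 180000 nM in this assay, at which 1 of the 3 values shown sits, or at the limit of > 63000 nM in this assay, at which 2 of the 3 values shown sit. Going by the values given here, they therefore show only that exchanging the group at this position among chloro, hydroxy and difluoromethoxy never brought a compound into the readable range of this assay. The same outcome is expected for the swap to dimethylamino, so the step that the limit leaves unreadable from compound 3 to compound 4 is expected to stay within the scatter, most likely as another limit.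

Compound 4 is estimated at 100000 nM in this assay, with a range from 30000 nM to 300000 nM.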

Compound 4, half-maximal inhibitory concentration: > 180000 nM
Compound 4: no number, only a limit; the forecaster's own chance of this, stated with the estimate: 80%; middle value at least 1.8-fold (0.25 log units) away from the limit.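

In this assay compound 4 gives > 180000 nM, which is a limit and not a number. With limits at both ends, the steps to compound 4 from compound 1, compound 2 and compound 3 cannot be read. The compounds shown leave open how chloro, hydroxy, difluoromethoxy and dimethylamino rank against one another, and what any of the four compounds' true potency is.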